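This account rests on a few compounds, and the source may have more. Where it says the series, first, only, none or still open, it means among the compounds named here.

Values so far in a functional assay, read by spectrophotometry; on this read-out lower numbers stand for an effect already at smaller amounts and higher numbers for an effect only at larger amounts of compound
- compound 1 `COc1ccc(-c2cc(=O)c3ccc(O)cc3o2)cc1OC` gives 22.4 nM
- compound 2 `COc1cc(-c2cc(=O)c3ccc(O)cc3o2)cc(OC)c1OC` gives 26.4 nM
- compound 3 `COc1ccc(-c2cc(=O)c3ccc(OCCCCN4CCC(CCO)CC4)cc3o2)cc1` gives 23.2 nM

All three values lie within the scatter of each other, so compound 3 at 23.2 nM stands level with the other two. The next compound is compound 4 `COc1ccc(-c2cc(=O)c3ccc(OCCCCCCCN4CCC(C)CC4)cc3o2)cc1`. The change is 3-(4-methylpiperidin-1-yl)propyl in place of 4-(2-hydroxyethyl)piperidin-1-yl on a saturated chain carbon, four bonds along the chain from an oxygen on an aromatic ring.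

Among the measured compounds shown here, the only measured step is a 1.2-fold higher number from compound 1 to compound 2 (0.07 log units; within the scatter). It is methoxy in place of hydrogen on an aromatic carbon, lies within the scatter and bears on this change only weakly, since it does not touch the chain. Compound 3 carries a chain that compound 1 lacks, yet compound 1 at 22.4 nM and compound 3 at 23.2 nM stay within the scatter of each other. That gives a weak reason to expect no shift beyond the scatter, and no direction can be argued from the data. The expected step is a 1.1-fold higher number from compound 3 to compound 4 (0.03 log units; within the scatter). For the measured compounds named here, no measured step covers a change of this kind, and the range is kept wide. For compound 4 the estimated value is 25 nM, with an expected range from 8 nM to 80 nM.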

Compound 4, half-maximal effective concentration: 42.6 nM
Compound 4: middle estimate off by 1.7-fold (0.23 log units), on the low side; low and high end bracket the measured number.
By their numbers in this assay, from the lowest: compounds 1, 3, 2 and 4 (each within the scatter of the next).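

In this assay, among the compounds shown here, 3-(4-methylpiperidin-1-yl)propyl in place of 4-(2-hydroxyethyl)piperidin-1-yl on a saturated chain carbon, four bonds along the chain from an oxygen on an aromatic ring, gives a 1.8-fold higher number from compound 3 to compound 4 (0.26 log units; within the scatter), the first step that touches the chain. This place therefore accepts a change in both the end group and the reach of the chain without leaving the scatter, even though the entering group has 0 hydrogen-bond donors and the leaving group has 1. No measurement at hand bears on why the numbers sit as they do.

On these data alone, the step changes the terminal substituent and the propyl extension together, so the contribution of each remains open, and a 2-hydroxyethyl-substituted piperidine on the extended chain or a 4-methylpiperidine on the shorter one would separate them. Also open, as far as these compounds go, is how this place responds to end groups of another type, such as a morpholine, a dimethylamino group or a carboxylic acid, since both chain-bearing compounds here end in a substituted piperidine.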